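Three limits in one assay and an unmeasured analogue

The source may hold more compounds than are shown below. What is called first, only, known or untested is meant among the compounds shown, and "the series" means these compounds.

Compound 1, `C=CCOc1cc(C2=C(c3cc(OC)c(OC)c(OC)c3)C(=O)C(O)C2)ccc1OC`: in an ADME assay on PA-1 cells (Homo sapiens) for cytotoxicity, read by MTT assay, with a stated time of 72 h (a lower number here means a stronger inhibitor, a higher number a weaker inhibitor), compound 1 gives > 100 ug/mL, a limit of the assay.
Compound 2, `COc1ccc(C2=C(c3cc(OC)c(OC)c(OC)c3)C(=O)C(O)C2)cc1NC(=O)c1ccccc1`: in this assay compound 2 gives > 100 ug/mL, a limit of the assay.
Compound 3, `COc1ccc(C2=C(c3cc(OC)c(OC)c(OC)c3)C(=O)C(O)C2)cc1Cl`: in this assay compound 3 gives > 100 ug/mL, a limit of the assay.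

Compound 3 stands at the limit of > 100 ug/mL in this assay, at which 3 of the 3 values shown sit, and no number is known for it. Among the measured pairs, the steps a step that the two limits leave unreadable from compound 1 to compound 3 and a step that the two limits leave unreadable from compound 2 to compound 3 lead to compound 3, and the step that the two limits leave unreadable from compound 1 to compound 2 links the other two; all three are unreadable in size, so none of them gives a readable measure of what a change at this position does in this assay.

The next compound is compound 4, `COc1ccc(C2=C(c3cc(OC)c(OC)c(OC)c3)C(=O)C(O)C2)cc1OC(C)C`. It differs from compound 3 as follows: isopropoxy in place of chloro on an aromatic carbon. Among the measured compounds shown here, no measured step reads on this change, and all three known values sit at the same limit, so the step from compound 3 to compound 4 is expected to be a step that the limit leaves unreadable from compound 3 to compound 4 in this assay, that is, no step beyond the scatter. Compound 4 is estimated at 130 ug/mL, within 50 ug/mL to 350 ug/mL, with a limit rather than a number the likelier outcome.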

Compound 4, half-maximal inhibitory concentration: > 100 ug/mL
Compound 4: only a limit was reported (the forecaster's own chance of this, stated with the estimate: 75%); the middle value does not contradict the limit.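

Compound 4 gives > 100 ug/mL in this assay, a limit of the assay, so the steps to it from compound 1, compound 2 and compound 3 cannot be read in size. The compounds shown leave open what number any of the four would give, and whether a change at this position matters at all.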